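The compounds below may be only part of what the source reports. "The series", "measured", "known", "first", "only" and "open" are said of these compounds alone.

Measured compounds:
compound 1 `O=c1cc(NC2CCCCC2)cc(/C=C/c2ccccc2)o1` — 1.53 uM
compound 2 `COc1cccc(Nc2cc(-c3ccccc3)oc(=O)c2)c1` — 0.74 uM

In a functional assay on SK-BR-3 cells (Homo sapiens) for cytotoxicity, read by MTT assay, with a stated time of 72 h (a higher number here means that more compound is needed for the effect, a lower number that less compound is needed), compound 1 gives 1.53 uM, the highest of the two numbers recorded. Its nearest neighbour is compound 2, which in this assay gives 0.74 uM; the gap between the two lies beyond the usual scatter. The two compounds differ in more than one place, so no single step can be read from them; what they show is that the member carrying a methoxy-bearing aromatic ring on the nitrogen sits at the lower number.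

Compound 3 `COc1ccc(Nc2cc(/C=C/c3ccccc3)oc(=O)c2)cc1` is not yet measured. It differs from compound 1 in one place: 4-methoxyphenyl in place of cyclohexyl on a nitrogen on an aromatic ring. This brings an aromatic, methoxy-bearing ring onto the nitrogen, as found in compound 2, while keeping the rest of compound 1 unchanged. Since compound 2 gives 0.74 uM against the higher value of compound 1, a modest move toward a lower number is expected, though without a clean matched step the size is uncertain and a result within the scatter would not surprise. The expected step from compound 1 to compound 3 is a 1.7-fold lower number from compound 1 to compound 3 (0.23 log units; within the scatter). For compound 3 the estimate in this assay is 0.9 uM, with a range from 0.4 uM to 2.5 uM.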

Compound 3, concentration for half-maximal effect: 0.083 uM
The estimate for compound 3 lay 11-fold (1.04 log units) above the measured number; the whole stated range lies above it.
By their numbers in this assay, from the lowest: compound 3; then compound 2; then compound 1.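

In this assay, for the compounds shown here, 4-methoxyphenyl in place of cyclohexyl on a nitrogen on an aromatic ring gives an 18-fold lower number from compound 1 to compound 3 (1.27 log units; beyond the scatter), the first step that can be read with the rest of the structure held fixed, and it shows that the group on this nitrogen strongly shifts the number in these cells. The pair of compound 1 and compound 2 could not show this, since those two differ in more than one place. The change replaces a six-membered non-aromatic carbon ring with a six-membered aromatic carbon ring carrying a methoxy group, and nothing at hand bears on why the number falls so far.

This single step does not separate the contribution of the aromatic ring from that of the methoxy group, which a plain phenyl on the same nitrogen would help to resolve. Also open, as far as these compounds go, is how far the position tolerates other groups on that ring, such as a dimethylamino group or a carboxylic acid, or a longer chain between the nitrogen and the ring, and whether the step carries over to other cell lines.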